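From an Aryl Amide to a Pyridinyl Amide

The source may report more compounds than this note shows. Statements on the series, on what has been measured and on what is new or still open speak of the compounds shown alone.

Three compounds share one core and differ only in the group on the amide-type nitrogen. Compound 1 `COc1cc2c(cc1OC)C(CC(=O)Nc1ccc(Br)cc1)CC2` gives 40.6% in a functional assay on the whole organism (strain Wistar) for inhibition, with Rattus norvegicus as the target, read by paw edema, with a stated time of 4 h, at a dose of 100 mg/kg; a lower number here means less inhibition, a higher number more inhibition at the dose given (going by the name of the read-out). Compound 2 `COc1cc2c(cc1OC)C(CC(=O)Nc1ccccc1C)CC2` gives 25%, and compound 3 `COc1ccccc1NC(=O)CC1CCc2cc(OC)c(OC)cc21` gives 23.4%. Both a number 15.6 percentage points lower from compound 1 to compound 2 (beyond the scatter) and a number 17.2 percentage points lower from compound 1 to compound 3 (beyond the scatter) were modest, while a number 1.6 percentage points lower from compound 2 to compound 3 (within the scatter) stayed within the scatter. Compound 3 thus stands lowest of the three, close to compound 2 and well below compound 1. Compound 4 `COc1cc2c(cc1OC)C(CC(=O)Nc1ccncc1)CC2` is compound 3 with pyridin-4-yl in place of 2-methoxyphenyl on an amide-type nitrogen. Among the measured compounds shown here, no measured step involves a pyridin-4-yl group; the two modest steps only show that the group on this nitrogen can shift the number. The expected step is a number 4.6 percentage points higher from compound 3 to compound 4 (within the scatter), with no clear direction. Compound 4 is estimated at 28%, between 12% and 45%.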

Compound 4, a percentage reported as inhibition, in the whole organism at one dose (the size of the read-out at that dose, not a potency): 45.3%
Beside the measured number, compound 4's estimate is 17.3 percentage points below it; the whole stated range lies below it.
By their numbers in this assay, from the lowest: compounds 3 and 2 (each within the scatter of the next); then compounds 1 and 4 (each within the scatter of the next).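

In this assay, pyridin-4-yl on the amide-type nitrogen gives a number 21.9 percentage points higher from compound 3 to compound 4 (beyond the scatter) and a number 20.3 percentage points higher from compound 2 to compound 4 (beyond the scatter), so a ring with a hetero atom at this position can reach well past the 2-methoxyphenyl and 2-methylphenyl groups. Yet a number 4.7 percentage points higher from compound 1 to compound 4 (within the scatter) shows that it stands level with the carbon-only 4-bromophenyl group, so a hetero atom in the ring is not required for this level. Nothing available here explains these steps. The compounds shown leave open how pyridin-3-yl or a cyclohexyl group would read on this nitrogen.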